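Hydroxymethyl to methylcarbamoyl: working notes on cytotoxicity

The source may hold more compounds than are shown below. What is called first, only, known or untested is meant among the compounds shown, and "the series" means these compounds.

In an ADME assay on TZM cells (Homo sapiens) for cytotoxicity, read by XTT assay, with a stated time of 4 days (on this read-out higher numbers stand for lower toxicity in this test and lower numbers for higher toxicity in this test), compound 1 `Cc1cc(/C=C/C#N)cc(C)c1Oc1cc(Nc2ccc(C#N)cc2)c(N)cc1C(N)=O` gives > 23600 nM, which is a limit of the assay and not a number. Among the compounds with values here, compound 2 `Cc1cc(/C=C/C#N)cc(C)c1Oc1cc(Nc2ccc(C#N)cc2)c(N)cc1CO` gives 16300 nM, the only true number available so far. Within the data shown here, the one measured step is an at least 1.4-fold lower number from compound 1 to compound 2 (0.16 log units; that floor lies within the scatter), with hydroxymethyl in place of carbamoyl on an aromatic carbon. Its evidence is thin, resting on (the limit of > 23600 nM in this assay, at which 1 of the 2 values shown sits).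

Compound 3 `CNC(=O)c1cc(N)c(Nc2ccc(C#N)cc2)cc1Oc1c(C)cc(/C=C/C#N)cc1C` has methylcarbamoyl in place of hydroxymethyl on an aromatic carbon, para to a (4-cyanophenyl)amino group: methylcarbamoyl in place of hydroxymethyl on an aromatic carbon. This change runs roughly opposite to an at least 1.4-fold lower number from compound 1 to compound 2 (0.16 log units; that floor lies within the scatter), so a small move towards a higher number in this assay is expected, probably not beyond the scatter. The estimated change is a 1.3-fold higher number from compound 2 to compound 3 (0.11 log units; within the scatter). Compound 3 is expected at 21000 nM, with an estimated range of 10000 nM to 42000 nM.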

Compound 3, half-maximal cytotoxic concentration in the TZM assay: > 9200 nM
Compound 3: a limit, no number; the forecaster's own chance of this, stated with the estimate: 45%; the middle value is on the limit's open side.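

In the TZM assay compound 3 gives > 9200 nM, a limit of the assay and not a number, so its steps from compound 1 and compound 2 cannot be read. The compounds shown leave open whether methylcarbamoyl, carbamoyl and hydroxymethyl differ at all on this read-out. In a physicochemical assay for solubility, with a stated time of 4 h, at pH 7.4 (a lower number here means a less soluble compound, a higher number a more soluble compound), compound 2 gives 3.23 ug/mL and compound 3 gives 1.32 ug/mL. In the physicochemical assay methylcarbamoyl in place of hydroxymethyl on an aromatic carbon gives a 2.4-fold lower number from compound 2 to compound 3 (0.39 log units; beyond the scatter).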